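Removing an Amino Group from a Slowly Cleared Core

This account rests on a few compounds, and the source may have more. Where it says the series, first, only, none or still open, it means among the compounds named here.

Compound 1 `CC(C)n1nc(-c2ccc3oc(N)nc3c2)c2c(CO)nc(N)nc21` and compound 2 `CC(C)n1nc(-c2ccc3oc(N)nc3c2)c2c(=O)[nH]c(N)nc21` share a core and were both run in an ADME assay on cells (Hepatocyte, Homo sapiens) for metabolic stability, read by LC-MS, with a stated time of 90 min, tested at 1 uM; a lower number here means slower removal, a higher number faster removal of the compound. In this assay compound 1 gives < 5 uL/min, which is a limit of the assay rather than a number. Compound 2 likewise gives < 5 uL/min, again a limit. So compound 2 stands at the lowest point the assay can report, and the one other value shown sits there too, as summed up in the limit of < 5 uL/min in this assay, at which 2 of the 2 values shown sit. For the measured compounds named here, no step between measured compounds is available. Compound 3 `CC(C)n1nc(-c2ccc3oc(N)nc3c2)c2c(=O)[nH]cnc21` differs from compound 2 by hydrogen in place of amino on an aromatic carbon. Going by the values given here, with both measured values at the limit, there is no measured step to lean on. The step that the limit leaves unreadable from compound 2 to compound 3 is expected to be none beyond the usual scatter. Compound 3 is therefore expected to give about 4 uL/min, with a range from 2 uL/min to 10 uL/min, and may again come back only as a limit.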

Compound 3, intrinsic clearance in a liver preparation (reported as CLH), per the amount of preparation that the assay uses in the Hepatocyte assay: < 5 uL/min
Compound 3 was reported as a limit (the forecaster's own chance of this, stated with the estimate: 60%); the middle value does not contradict the limit.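

For the compounds shown here, in the Hepatocyte assay compound 2 and compound 3 both sit at the limit of the assay, so no step between them can be read. In a physicochemical assay for solubility, read by HPLC, in phosphate buffer, measured as kinetic solubility, with a stated time of 24 h, at 20 degrees C, at pH 7.4, tested at 100 uM (a lower number here means a less soluble compound, a higher number a more soluble compound), compound 2 gives 9200 nM and compound 3 gives 3000 nM. The compounds shown leave open the true rate of removal of all three, and whether hydrogen in place of amino changes it.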